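Aminophenyl to Phenylethyl on the Shared Core

This account rests on a few compounds, and the source may have more. Where it says the series, first, only, none or still open, it means among the compounds named here.

Compound 1 `Nc1ccc(Nc2c(C(=O)NCc3ccc(F)cc3)nc(Br)c3cccnc23)cc1` gives 7000 nM in a functional assay on MDA-MB-435 cells (Homo sapiens) for cytotoxicity, read by MTT assay, with a stated time of 72 h (on this read-out lower numbers stand for stronger inhibition and higher numbers for weaker inhibition), and stands as the higher of the two numbers here; compound 2 `N[C@H]1CC[C@H](Nc2c(C(=O)NCc3cccs3)nc(Br)c3cccnc23)CC1` gives 4100 nM, a gap that lies within the scatter. For the measured compounds named here, no step between measured compounds that differ in one place is available. Compound 3 `C[C@H](Nc1c(C(=O)NCc2ccc(F)cc2)nc(Br)c2cccnc12)c1ccccc1` differs from compound 1 by 1-phenylethyl in place of 4-aminophenyl on a nitrogen on an aromatic ring. Going by the values given here, with no comparable step in hand, no shift clearly beyond the scatter is expected, in either direction. Compound 3 is estimated at 5000 nM, with a range of 1500 nM to 16000 nM. The expected step is a 1.4-fold lower number from compound 1 to compound 3 (0.15 log units; within the scatter).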

Compound 3, half-maximal inhibitory concentration: > 20000 nM
Compound 3: no number, only a limit; the forecaster's own chance of this, stated with the estimate: 5%; middle value at least 4.0-fold (0.60 log units) from the limit.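

In this assay compound 3 reads > 20000 nM, which is a limit of the assay and not a number. For the compounds shown here, on a nitrogen on an aromatic ring, 1-phenylethyl in place of 4-aminophenyl gives an at least 2.8-fold higher number from compound 1 to compound 3 (0.45 log units; beyond the scatter), the first one-place change, and it points toward weaker inhibition. Only a minimum can be given for the size of this step: the limit of > 20000 nM in this assay, at which 1 of the 3 values shown sits.

From the compounds shown here alone, whether the step goes with the loss of the amine, the added branch or the defined stereocentre stays open. An unsubstituted phenyl or a plain benzyl on that nitrogen would separate these.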